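Chlorinated to Iodinated Thiophene Ketone on a Quinoline Core

The source may report more compounds than this note shows. Statements on the series, on what has been measured and on what is new or still open speak of the compounds shown alone.

Measured so far:
- Compound 1, `Cc1ccc2nc(Cl)c(/C=C/C(=O)c3cc(C)sc3C)cc2c1`, gives 229 nM in a functional assay on HUVEC cells (Homo sapiens), read by BrdU incorporation, with a stated time of 72 h; on this read-out lower numbers stand for stronger inhibition and higher numbers for weaker inhibition.
- Compound 2, `Cc1ccc2nc(Cl)c(/C=C/C(=O)c3cc(Cl)sc3Cl)cc2c1`, gives 26.2 nM in this assay.

Compound 2 holds the lowest of the two numbers seen so far, and its nearest neighbour is compound 1, separated by a step that lies beyond the scatter. Going by the values given here, the one measured step, an 8.7-fold lower number from compound 1 to compound 2 (0.94 log units; beyond the scatter), shows that exchanging the two methyl groups on the thiophene ring for two chlorine atoms made the number fall in a modest but clear way.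

Compound 3, `Cc1ccc2nc(Cl)c(/C=C/C(=O)c3ccc(I)s3)cc2c1`, has not yet been measured. It differs from compound 2 by 5-iodothiophen-2-yl in place of 2,5-dichlorothiophen-3-yl on a carbonyl carbon. This is a different kind of change from the measured step: the ring is now joined to the carbonyl through a different ring carbon, and it carries a single iodine rather than two chlorines. Among the compounds with values here, no measured pair speaks to this change directly; the step from compound 1 to compound 2 says only that the pattern on the thiophene matters.

With no direct guidance, compound 3 is expected to land near compound 2, with a wide range: 55 nM, between 15 nM and 250 nM, a step of a 2.1-fold higher number from compound 2 to compound 3 (0.32 log units; beyond the scatter) that is expected to be no more than modest.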

Compound 3, half-maximal inhibitory concentration: 129 nM
Beside the measured number, compound 3's estimate is 2.3-fold (0.37 log units) below it, and the stated range covers the measured number.
By their numbers in this assay, from the lowest: compound 2; then compounds 3 and 1 (each within the scatter of the next).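

In this assay, putting 5-iodothiophen-2-yl in place of 2,5-dichlorothiophen-3-yl on the carbonyl carbon gives a 4.9-fold higher number from compound 2 to compound 3 (0.69 log units; beyond the scatter) and so gives up much of the drop that the two chlorines brought. Against the dimethyl group, the same iodinated thiophene gives a 1.8-fold lower number from compound 1 to compound 3 (0.25 log units; within the scatter) and stays within the usual scatter, so 5-iodothiophen-2-yl and 2,5-dimethylthiophen-3-yl cannot be told apart here, and having a halogen on the thiophene does not by itself reach the number of compound 2. No supporting data are available to explain why these thiophene groups differ.

Compound 2 and compound 3 differ in both the halogen and the way the thiophene is attached to the carbonyl carbon, so the compounds shown cannot say which of these differences matters. They also leave open how a thiophene carrying an amine or a carboxylic acid, or a plain phenyl ring in its place, would read on the same shared core.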